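A few compounds are considered here, and "the series" means these few. Any claim that something is new, unique, unknown or untested is made for them only; others in the source may bear on it.

Measured so far in this set:
compound 1 `O=c1[nH]c(=O)n(CCC(CO)CO)cc1-c1cccs1`: > 100000 nM
compound 2 `CCCCCC#Cc1cn(CCC(COC(C)=O)COC(C)=O)c(=O)n(C(=O)c2ccccc2)c1=O`: 40700 nM
compound 3 `CC(=O)OCC(CCn1cc(C#CC(C)(C)C)c(=O)n(C(=O)c2ccccc2)c1=O)COC(C)=O`: > 100000 nM

In a functional assay on SW-620 cells (Homo sapiens) for antiproliferative activity, read by MTT assay, with a stated time of 72 h (on this read-out higher numbers stand for weaker inhibition and lower numbers for stronger inhibition), compound 1 gives only a limit, > 100000 nM, so its place among the three is not fixed by a number. Compound 3 likewise gives only a limit, > 100000 nM. Compound 2 gives 40700 nM. Among the measured compounds shown here, the single measured step, an at least 2.4-fold higher number from compound 2 to compound 3 (0.39 log units; beyond the scatter), concerns a group on a triple-bonded carbon and not the change in hand. Compound 4 `CC(C)(C)C#Cc1cn(CCC(CO)CO)c(=O)[nH]c1=O` differs from compound 1 by 3,3-dimethylbut-1-yn-1-yl in place of thiophen-2-yl on an aromatic carbon. For the measured compounds named here, no measured step follows this change, but the entering group is the one carried by compound 3, and because of the limit of > 100000 nM in this assay, at which 2 of the 3 values shown sit, a further limit is the likeliest outcome. Compound 4 is therefore expected to remain weak, the estimated step that the limit leaves unreadable from compound 1 to compound 4 meaning no clear change, with an estimate of 200000 nM (50000 nM to 1000000 nM).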

Compound 4, half-maximal inhibitory concentration: > 100000 nM
Compound 4: no number, only a limit; the forecaster's own chance of this, stated with the estimate: 80%; the middle value does not contradict the limit.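

Among the compounds shown here, compound 1 and compound 4 each give only a limit and not a number, so no step between them can be read. From the compounds shown here alone, whether thiophen-2-yl or 3,3-dimethylbut-1-yn-1-yl gives stronger inhibition remains open.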